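Sulfonamide amine variation in a trifluoromethyl hydroxyamide series

The source may hold more compounds than are shown below. What is called first, only, known or untested is meant among the compounds shown, and "the series" means these compounds.

Measured so far in an assay on a protein complex (Cavia porcellus) with sulfonylurea receptors; K-ATP channels (Homo sapiens) as the target; a lower number here means a stronger inhibitor, a higher number a weaker inhibitor:
compound 1 `Cn1nnnc1-c1ccc(NC(=O)C(C)(O)C(F)(F)F)cc1` — compound 1 gives 30900 nM
compound 2 `CC(C)CN(CC(C)C)S(=O)(=O)c1ccc(NC(=O)C(C)(O)C(F)(F)F)cc1` — compound 2 gives > 30000 nM, a limit of the assay
compound 3 `CC(O)(C(=O)Nc1ccc([C@H](O)c2ccccc2)cc1)C(F)(F)F` — compound 3 gives > 30000 nM, a limit of the assay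

Compound 2 stands at the limit of > 30000 nM in this assay, at which 2 of the 3 values shown sit, so no number for it is known. Among the compounds with values here, the only step between measured compounds, a step that the limit leaves unreadable from compound 1 to compound 3, is unreadable for the same reason and does not touch the sulfonyl substituent. Compound 4 `CCCN(CCC)S(=O)(=O)c1ccc(NC(=O)C(C)(O)C(F)(F)F)cc1` carries dipropylamino in place of diisobutylamino on a sulfonyl sulfur. Within the data shown here, no measured step varies this group, so no size can be read across for it. Compound 4 is therefore expected to sit near the limit again, estimated at 30000 nM with a range of 8000 nM to 120000 nM. The expected step of a number no higher from compound 2 to compound 4 (the limit leaves the size open) is none beyond the scatter.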

Compound 4, half-maximal inhibitory concentration: 6440 nM
Estimate against measurement, compound 4: 4.7-fold (0.67 log units) above, and the stated range ends above it.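

In this assay, the sulfonyl sulfur now shows a change that can be read: dipropylamino in place of diisobutylamino gives an at least 4.6-fold lower number from compound 2 to compound 4 (0.66 log units; beyond the scatter). Compound 2 gives > 30000 nM, which is a limit of the assay, so only a minimum size is known for this step. The earlier compounds shown here did not vary this group, and this pair shows that changing the two chains on the sulfonamide nitrogen alone can move the number beyond the scatter.

On these data alone, whether the number keeps falling with shorter chains, as in diethylamino, remains open. So does how a ring amine such as piperidine would behave at this sulfonyl sulfur.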